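Metabolic Stability of Compound 4 After a Side-Chain Swap

The compounds below may be only part of what the source reports. "The series", "measured", "known", "first", "only" and "open" are said of these compounds alone.

Among the measured compounds shown here, compound 3 `CCCCCOC(=O)N1CCN(C(=O)[C@H](CCC(=O)O)NC(=O)c2cc(N3CCC(OCCO)CC3)nc(-c3ccccc3)n2)CC1` is one of three compounds measured in an ADME assay on microsomes from liver (Homo sapiens) for metabolic stability; on this read-out lower numbers stand for a less stable compound and higher numbers for a more stable compound. In this assay compound 3 gives > 80%, which is a limit of the assay rather than a number. Compound 1 `CCCCCOC(=O)N1CCN(C(=O)[C@H](CCC(=O)O)NC(=O)c2cc(N3CCC(C(=O)N(CC)CC)CC3)nc(-c3ccccc3)n2)CC1` gives > 80% in this assay, again a limit. Compound 2 `CCCCCOC(=O)N1CCN(C(=O)[C@H](CCC(=O)O)NC(=O)c2cc(N3CCC(C(=O)NCC)CC3)nc(-c3ccccc3)n2)CC1` gives > 80%, also a limit. Because (the limit of > 80% in this assay, at which 3 of the 3 values shown sit), the steps a step that the two limits leave unreadable from compound 1 to compound 2, a step that the two limits leave unreadable from compound 1 to compound 3 and a step that the two limits leave unreadable from compound 2 to compound 3 cannot be sized, and no ranking of the three compounds can be read from them.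

Compound 4 `CCCCCOC(=O)N1CCN(C(=O)[C@H](CCC(=O)O)NC(=O)c2cc(N3CCC(COC)CC3)nc(-c3ccccc3)n2)CC1` has not yet been measured. It differs from compound 3 by methoxymethyl in place of 2-hydroxyethoxy on a saturated ring carbon. The three measured steps all concern changes at this same saturated ring carbon and bear on the new change, but none of them is readable, so they set no direction and no size. What they do show is that three different groups at this position all left the compound at the limit. Compound 4 is therefore expected to give about 85% in this assay, in a range from 70% to 95%. The step that the limit leaves unreadable from compound 3 to compound 4 is expected to be none beyond the usual scatter.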

Compound 4, percent of the compound remaining: > 80%
Compound 4 was reported as a limit (the forecaster's own chance of this, stated with the estimate: 70%); the middle value does not contradict the limit.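

Among the compounds shown here, no step from compound 1, compound 2 or compound 3 to compound 4 can be read, because all four compounds share one limit rather than a number: the limit of > 80% in this assay, at which 4 of the 4 values shown sit. The compounds shown leave open whether the groups on the saturated ring carbon differ at all in this assay, and in what order.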